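This account rests on a few compounds, and the source may have more. Where it says the series, first, only, none or still open, it means among the compounds named here.

Among the measured compounds shown here, compound 3 `O=C(CN1CCN(c2ccc(Cl)cn2)CC1)Nc1cccnc1` gives 23500 nM in an assay on cells for antagonist activity at D(4) dopamine receptor (Homo sapiens), read by luminescence and beta-arrestin recruitment, with a stated time of 90 min (on this read-out lower numbers stand for stronger inhibition and higher numbers for weaker inhibition), the highest number of the three measured so far. Compound 1 `Cc1cccc(NC(=O)CN2CCN(c3ccc(Cl)cn3)CC2)c1` gives 7780 nM and compound 2 `CCc1cccc(NC(=O)CN2CCN(c3ccc(Cl)cn3)CC2)c1` gives 10400 nM; the step of a 1.3-fold higher number from compound 1 to compound 2 (0.13 log units; within the scatter) is the only one in the set that stays within the scatter. The steps that lead to compound 3 both point the same way: a 3.0-fold higher number from compound 1 to compound 3 (0.48 log units; beyond the scatter) and a 2.3-fold higher number from compound 2 to compound 3 (0.35 log units; beyond the scatter), so a six-membered aromatic ring with one hetero atom on the amide-type nitrogen, in place of a substituted phenyl, has twice raised the number.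

Compound 4 `O=C(CN1CCN(c2ccc(Cl)cn2)CC1)Nc1cncnc1` carries this one bond further in the same direction: pyrimidin-5-yl in place of pyridin-3-yl on an amide-type nitrogen. For the measured compounds named here, no measured pair shows the effect of a second ring nitrogen at this position, so the size of the step is uncertain. Given that both steps towards compound 3 weakened inhibition, a further modest rise is expected, about a 1.7-fold higher number from compound 3 to compound 4 (0.23 log units; within the scatter). Compound 4 is therefore estimated at 40000 nM, with a range from 15000 nM to 100000 nM, and a real chance that only a limit is returned.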

Compound 4, half-maximal inhibitory concentration: > 100000 nM
Compound 4 ended at the assay's limit; the forecaster's own chance of this, stated with the estimate: 30%; middle value at least 2.5-fold (0.39 log units) away from the limit.
By their numbers in this assay, from the lowest: compounds 1 and 2 (each within the scatter of the next); then compound 3. At a limit, above all of these: compound 4.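

The value for compound 4 is a limit of the assay, not a number: the limit of > 100000 nM in this assay, at which 1 of the 4 values shown sits.

With pyrimidin-5-yl in place of pyridin-3-yl on the amide-type nitrogen, the ring goes from 1 hetero atom to 2, and the result is an at least 4.2-fold higher number from compound 3 to compound 4 (0.62 log units; beyond the scatter). Among the compounds shown here, this is the first step between two heteroaromatic rings at this position, and it shows that pyridin-3-yl was not the end of the loss. Against the substituted phenyl groups, the same ring gives an at least 9.6-fold higher number from compound 2 to compound 4 (0.98 log units; beyond the scatter) and an at least 12-fold higher number from compound 1 to compound 4 (1.10 log units; beyond the scatter), so across these four compounds each added ring hetero atom goes with a higher number, and none goes against this.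

The size of these steps is known only as a bound. Going by these compounds, it remains open whether a methyl or ethyl group on the pyrimidin-5-yl ring would bring the number back down, and where an unsubstituted phenyl would fall at this position.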